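Shortening the Chain Between Core and Aryl Group

This account rests on a few compounds, and the source may have more. Where it says the series, first, only, none or still open, it means among the compounds named here.

The three measured compounds were compared in a functional assay on FM3A cells (Mus musculus) for inhibition, read by cell counting, with a stated time of 2 days; on this read-out lower numbers stand for stronger inhibition and higher numbers for weaker inhibition. Compound 1 `C=C(Br)C(=O)Nc1cccc(-c2cn3nc(-c4ccc(F)cc4)sc3n2)c1` gives 610 nM in this assay. Compound 2 `CCOc1ccc(-c2nn3cc(-c4cccc(N)c4)nc3s2)cc1` does not yield a number; in this assay compound 2 is reported only as >= 250000 nM, which is a limit of the measurement (the limit of >= 250000 nM in this assay, at which 1 of the 3 values shown sits). Compound 3 `Nc1cccc(-c2cn3nc(CCc4ccccc4)sc3n2)c1` gives 29000 nM in this assay, the higher of the two numbers obtained, with compound 1 standing far below it, well beyond the scatter of repeated measurements.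

Compound 4 `COc1ccc(Cc2nn3cc(-c4cccc(N)c4)nc3s2)cc1` has not yet been measured. It differs from compound 3 in one place: 4-methoxyphenyl in place of benzyl on a saturated chain carbon bound to an aromatic carbon. No pair of measured compounds makes this same change, so its size cannot be read from the numbers shown, and the limit seen for compound 2 gives no number to lean on.

Compound 4 is therefore expected to remain close to compound 3, with the step of a 1.4-fold higher number from compound 3 to compound 4 (0.14 log units; within the scatter) estimated to fall within the usual scatter or slightly toward weaker inhibition. Compound 4 is estimated at 40000 nM, within a range from 10000 nM to 200000 nM.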

Compound 4, half-maximal inhibitory concentration: 100000 nM
Compound 4: middle estimate off by 2.5-fold (0.40 log units), on the low side, within the range that was stated.
By their numbers in this assay, from the lowest: compound 1; then compound 3; then compound 4. At a limit, above all of these: compound 2.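

In this assay, the exchange of benzyl for 4-methoxyphenyl on a saturated chain carbon bound to an aromatic carbon is the only step shown at this position, and it amounts to a 3.4-fold higher number from compound 3 to compound 4 (0.54 log units; beyond the scatter). This shows that the position responds to the change, modestly and toward weaker inhibition, which the earlier compounds could not show because no measured pair among them differed in one place: the limit of >= 250000 nM in this assay, at which 1 of the 4 values shown sits. The measured values give a size and a direction for the step, but nothing listed accounts for it.

On these data alone, what stays open is which part of the exchange carries the step, as this single pair does not separate the entering oxygen from the rest of the change. Nor do the compounds shown tell how the read-out would move with a plain phenyl, a hydroxyl, an amine or a longer chain at this position, so the one step cannot be taken as a trend.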